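Swapping the Aromatic Group on a Saturated Ring Carbon

The compounds below may be only part of what the source reports. "The series", "measured", "known", "first", "only" and "open" are said of these compounds alone.

Three compounds share one core and differ only in the group on a saturated ring carbon. Compound 1 `CCCCCCCCCCCCCCCCCCNC(=O)[C@H]1CSC(C2CCCCC2)N1` carries a cyclohexyl there; in a functional assay on DU-145 cells (Homo sapiens) for antiproliferative activity, read by sulforhodamine B assay (on this read-out lower numbers stand for stronger inhibition and higher numbers for weaker inhibition), compound 1 gives only a limit, > 20000 nM, and the limit of > 20000 nM in this assay, at which 1 of the 3 values shown sits, marks that limit. Compound 2 `CCCCCCCCCCCCCCCCCCNC(=O)[C@H]1CSC(Cc2ccccc2)N1` carries a benzyl and gives 15300 nM in this assay. Compound 3 `CCCCCCCCCCCCCCCCCCNC(=O)[C@H]1CSC(c2c[nH]c3ccccc23)N1` carries a 1H-indol-3-yl and gives 8900 nM in this assay, the lowest of the two numbers, though the gap is a 1.7-fold lower number from compound 2 to compound 3 (0.24 log units; within the scatter) and stays within the scatter. From the limit of compound 1 the move is an at least 2.2-fold lower number from compound 1 to compound 3 (0.35 log units; beyond the scatter).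

Compound 4 `CCCCCCCCCCCCCCCCCCNC(=O)[C@H]1CSC(c2ccc([N+](=O)[O-])cc2)N1` is the next step: 4-nitrophenyl in place of 1H-indol-3-yl on a saturated ring carbon. The steps seen so far show that exchanging this group shifts the numbers only modestly: an at least 1.3-fold lower number from compound 1 to compound 2 (0.11 log units; that floor lies within the scatter) and a 1.7-fold lower number from compound 2 to compound 3 (0.24 log units; within the scatter) both sit inside the scatter, and only an at least 2.2-fold lower number from compound 1 to compound 3 (0.35 log units; beyond the scatter) passes beyond it. A change from one aromatic group to another is therefore expected to move the number little, if at all, and more likely toward a higher value than a lower one. Compound 4 is estimated at 12000 nM in this assay, in a range from 5000 nM to 25000 nM. That estimate means a step of a 1.3-fold higher number from compound 3 to compound 4 (0.13 log units; within the scatter), expected to lie within or just beyond the scatter.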

Compound 4, half-maximal inhibitory concentration: 15300 nM
Estimate against measurement, compound 4: 1.3-fold (0.11 log units) below; the range from low to high includes it.
By their numbers in this assay, from the lowest: compounds 3, 2 and 4 (each within the scatter of the next). At a limit, above all of these: compound 1.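

In this assay, the 4-nitrophenyl lacks both the five-membered aromatic ring and the hydrogen-bond donor of the 1H-indol-3-yl and brings hydrogen-bond acceptors instead, yet this exchange on the saturated ring carbon gives only a small step (a 1.7-fold higher number from compound 3 to compound 4 (0.24 log units; within the scatter)), so those differences leave no effect that can be told from the scatter. The comparison with benzyl (no change at the digits printed from compound 2 to compound 4 (within the scatter)) likewise separates nothing, and the comparison with cyclohexyl (an at least 1.3-fold lower number from compound 1 to compound 4 (0.11 log units; that floor lies within the scatter)) rests on a limit for compound 1, so the 4-nitrophenyl adds a third aromatic group at this position without setting any of them apart from compound 4. Nothing in the information at hand bears on why these groups sit so close together in this assay.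

Going by these compounds, whether an amine or a carboxylic acid on the aromatic ring at this carbon would move the number beyond the scatter remains open. Since the long chain on the amide is the same throughout, it is also open how a shorter chain there would change the values of these compounds.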